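The source may report more compounds than this note shows. Statements on the series, on what has been measured and on what is new or still open speak of the compounds shown alone.

In an assay on Sf9 cells for inhibition of protein deacetylase HDAC6 (Homo sapiens), read by fluorescence (on this read-out lower numbers stand for stronger inhibition and higher numbers for weaker inhibition), compound 2 `Nc1ccc(-c2nnn(Cc3c(F)cc(C(=O)NO)cc3F)n2)cc1` gives 3 nM. The smaller compounds sit far higher: compound 3 `Nc1ccc(C(=O)NO)cc1` gives 1400 nM, and compound 1 `NCc1ccc(C(=O)NO)cc1` gives 695 nM. How the core of compound 2 differs from that of compound 3 is not broken down here. The change from compound 3 to compound 1, (aminomethyl in place of amino on an aromatic carbon), made a step of a 2.0-fold lower number from compound 3 to compound 1 (0.30 log units; within the scatter). Compound 4 `NCc1ccc(-c2nnn(Cc3c(F)cc(C(=O)NO)cc3F)n2)cc1` carries the same kind of change on the core of compound 2, (aminomethyl in place of amino on an aromatic carbon); the surroundings differ, the group sitting para to a large group in compound 4 and para to a group of 4 heavy atoms in compound 1. An expected step of a 1.2-fold lower number from compound 2 to compound 4 (0.08 log units; within the scatter) rests on the earlier step of a 2.0-fold lower number from compound 3 to compound 1 (0.30 log units; within the scatter). Compound 4 is therefore expected to give 2.5 nM, estimated between 0.8 nM and 8 nM in this assay.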

Compound 4, half-maximal inhibitory concentration: 4 nM
Beside the measured number, compound 4's estimate is 1.6-fold (0.20 log units) below it; measured number inside the range.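

In this assay, aminomethyl in place of amino on the core of compound 2 gives a 1.3-fold higher number from compound 2 to compound 4 (0.12 log units; within the scatter), so on this core the swap leaves the number within the usual scatter. Set beside the earlier step on the smaller core, the change does not carry over as one fixed step: the same change on two cores in this assay, a 2.0-fold lower number (0.30 log units; within the scatter) from compound 3 to compound 1 and a 1.3-fold higher number (0.12 log units; within the scatter) from compound 2 to compound 4, 2.7-fold (0.43 log units) apart, beyond the scatter of two such steps. Among the compounds shown here, with a single pair on each core, this shows only that the two steps differ, not how the change would behave on any further core or what lies behind the gap.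

On these data alone, it remains open whether a longer chain such as aminoethyl, or a carboxylic acid in place of the amine, would keep the number close to that of compound 2. Which part of the core of compound 2 sets it so far from compound 3 also remains open.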